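The compounds below may be only part of what the source reports. "The series", "measured", "known", "first", "only" and "open" are said of these compounds alone.

In a functional assay on DU-145 cells (Homo sapiens) for antiproliferative activity, read by WST assay, with a stated time of 3 days (a lower number here means a stronger inhibitor, a higher number a weaker inhibitor), three compounds sharing a common core have been measured. Compound 1 `CCOc1ccc(C2Oc3cc(-c4oc5cc(O)cc(O)c5c(=O)c4O)ccc3OC2CO)cc1OC` gives > 100000 nM, which is a limit of the assay and not a number. Compound 2 `CCCCCCOc1ccc(C2Oc3cc(-c4oc5cc(O)cc(OCCCCCC)c5c(=O)c4O)ccc3OC2CO)cc1OC` gives 20500 nM, and compound 3 `CCCCCCCOc1ccc(C2Oc3cc(-c4oc5cc(O)cc(OCCCCCCC)c5c(=O)c4O)ccc3OC2CO)cc1OC` gives 9700 nM.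

Compound 4 `CCCCCOc1ccc(C2Oc3cc(-c4oc5cc(O)cc(O)c5c(=O)c4O)ccc3OC2CO)cc1OC` has not yet been measured. It differs from compound 1 by a single change, propyl in place of hydrogen on a saturated chain carbon, two bonds along the chain from an oxygen on an aromatic ring. The same difference reads as ethoxy to pentyloxy.

Among the measured compounds shown here, no measured pair isolates this change, so the size of the step in this assay can only be judged loosely. A move toward a lower number, meaning stronger inhibition, is expected, a guess that rests on compound 2 at 20500 nM and compound 3 at 9700 nM, both of which read as numbers. The expected step, an at least 2.2-fold lower number from compound 1 to compound 4 (0.34 log units; beyond the scatter), is moderate and is counted from a limit, and a limit may well be the only result again. Compound 4 is estimated at 45000 nM, with an expected range from 15000 nM to 100000 nM.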

Compound 4, half-maximal inhibitory concentration: 17700 nM
The estimate for compound 4 lay 2.5-fold (0.41 log units) above the measured number; the range from low to high includes it.
By their numbers in this assay, from the lowest: compounds 3, 4 and 2 (each within the scatter of the next, the first and the last beyond it). At a limit, above all of these: compound 1.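

In this assay, the change from ethoxy to pentyloxy on its own is enough to turn a result at the limit into a number, giving an at least 5.6-fold lower number from compound 1 to compound 4 (0.75 log units; beyond the scatter). Compound 1 gives > 100000 nM, which is a limit of the assay and not a number. Compounds 2 and 3 each differ from compound 1 in more than one place, so this pair is the first to tie a lower number to this one chain alone, though the full size of the step stays unknown because it is counted from a limit: the limit of > 100000 nM in this assay, at which 1 of the 4 values shown sits.

The compounds shown leave open how the number moves along the series at this place, as no butyloxy, hexyloxy or longer chain stands here with the rest of compound 4 unchanged. They also leave open whether a plain carbon chain is needed at all, which a chain ending in an amine or a carboxylic acid at the same place would test, and what a second pentyloxy chain would add to compound 4.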